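A few compounds are considered here, and "the series" means these few. Any claim that something is new, unique, unknown or untested is made for them only; others in the source may bear on it.

Measured so far, in an ADME assay on the whole organism with Oryza sativa as the target, tested at 1 uM; a higher number here means a weaker effect of the compound at the concentration tested, a lower number a stronger effect:
compound 1, `CC(C)c1ccc(NC(=O)N[C@@H](C)c2ccccc2)cc1`, gives 96%;
compound 2, `CCCCc1ccc(NC(=O)N[C@@H](C)c2ccccc2)cc1`, gives 72%;
compound 3, `C[C@H](NC(=O)Nc1ccc(F)cc1)c1ccccc1`, gives 97%.

Compound 3 stands together with compound 1 (a number 1 percentage points higher from compound 1 to compound 3 (within the scatter)), and both stand above compound 2 (a number 25 percentage points higher from compound 2 to compound 3 (beyond the scatter)). Compound 4, `C[C@H](NC(=O)Nc1ccc(F)cc1F)c1ccccc1`, differs from compound 3 in one place: fluoro in place of hydrogen on an aromatic carbon. Among the compounds with values here, no measured step adds a fluoro where hydrogen stood; the known steps exchange one substituent for another on the same aromatic carbon, and the largest of them, a number 24 percentage points lower from compound 1 to compound 2 (beyond the scatter), is only modest, while a number 1 percentage points higher from compound 1 to compound 3 (within the scatter) lies within the scatter. A second fluoro on the ring that already carries one is therefore expected to leave the read-out in this assay close to that of compound 3, with no step beyond the scatter. Compound 4 is estimated at 95%, between 85% and 100%, an expected step of a number 2 percentage points lower from compound 3 to compound 4 (within the scatter).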

Compound 4, a percentage reported as activity, at one concentration (the size of the read-out at that concentration, not a potency): 100%
Compound 4: the middle estimate sits 5 percentage points below what was measured; the range from low to high includes it.
By their numbers in this assay, from the lowest: compound 2; then compounds 1, 3 and 4 (each within the scatter of the next).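

In this assay, fluoro in place of hydrogen on an aromatic carbon, ortho to a large group, gives a number 3 percentage points higher from compound 3 to compound 4 (within the scatter), the only step shown that adds a group where hydrogen stood. This position therefore accepts a fluoro with no change in the read-out beyond the scatter. No supporting measurement bears on this result.

Still open, on these data alone, is whether a methoxy group or a longer chain on this same carbon would lower the number, as butyl in place of isopropyl did, with a number 24 percentage points lower from compound 1 to compound 2 (beyond the scatter).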